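Ortho methyl on the N-aryl ring of the triazole series

The compounds below may be only part of what the source reports. "The series", "measured", "known", "first", "only" and "open" are said of these compounds alone.

Of the compounds shown here, three have been read in a functional assay on PC-12 cells (Rattus norvegicus) for cytotoxicity, read by MTT assay, with stated times of 2 h and 24 h, tested at 5 uM; a higher number here means a stronger effect of the compound at the concentration tested, a lower number a weaker effect. Compound 1 `Cc1ccc(-n2nc(-c3ccc(C(F)(F)F)cc3O)nc2-c2ccccc2O)cc1` gives 94.1% in this assay, which places it second highest of the three numbers shown; its nearest neighbour is compound 3 `COc1cccc(-n2nc(-c3ccc(C(F)(F)F)cc3O)nc2-c2ccccc2O)c1`, at 96.8%, and its furthest is compound 2 `COc1ccccc1-n1nc(-c2ccc(C(F)(F)F)cc2O)nc1-c1ccccc1O`, at 85.6%. Both gaps stay within the scatter: a number 2.7 percentage points higher from compound 1 to compound 3 (within the scatter) and a number 8.5 percentage points lower from compound 1 to compound 2 (within the scatter). Among the measured compounds shown here, only the step between the two methoxy compounds is beyond it, a number 11.2 percentage points higher from compound 2 to compound 3 (beyond the scatter).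

For the measured compounds named here, compound 4 `Cc1ccc(-n2nc(-c3ccc(C(F)(F)F)cc3O)nc2-c2ccccc2O)c(C)c1` has not yet been read. It differs from compound 1 as follows: methyl in place of hydrogen on an aromatic carbon, placed on an aromatic carbon of a six-membered aromatic ring of carbon only, ortho to a large group and meta to a methyl group. Going by the values given here, no measured step adds a group while keeping the rest of the ring; the closest analogy is the change to a ring substituted at the position ortho to the large group in compound 2, whose step from compound 1 lay within the scatter. The step of a number 4.1 percentage points lower from compound 1 to compound 4 (within the scatter) is therefore expected to be small, if anything slightly downward. Compound 4 is estimated at 90% in this assay, with a range from 80% to 98%.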

Compound 4, a percentage reported as activity, at one concentration (the size of the read-out at that concentration, not a potency): 93.3%
Beside the measured number, compound 4's estimate is 3.3 percentage points below it, and the stated range covers the measured number.
By their numbers in this assay, from the lowest: compounds 2, 4, 1 and 3 (each within the scatter of the next, the first and the last beyond it).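

Methyl in place of hydrogen, ortho to a large group and meta to a methyl group, is the only step shown that adds a group while keeping the rest of the ring; in this assay it reads as a number 0.8 percentage points lower from compound 1 to compound 4 (within the scatter) and leaves 2,4-dimethylphenyl indistinguishable from 4-methylphenyl. Compound 4 also separates from neither methoxy compound, with a number 3.5 percentage points lower from compound 3 to compound 4 (within the scatter) and a number 7.7 percentage points higher from compound 2 to compound 4 (within the scatter) both printed within the scatter, although the two methoxy compounds themselves stand apart by a number 11.2 percentage points higher from compound 2 to compound 3 (beyond the scatter) and are not separated through it. No available evidence accounts for these readings.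

The compounds shown leave open whether an amine, a carboxylic acid or a longer chain at this place would give a step beyond the scatter. Also open, as far as these compounds go, is whether any change here would matter at a concentration other than the one tested.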